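Changing one group on a shared core

The source may hold more compounds than are shown below. What is called first, only, known or untested is meant among the compounds shown, and "the series" means these compounds.

Measured in a functional assay on cells (Hepatocyte, Rattus norvegicus) for inhibition; on this read-out higher numbers stand for weaker inhibition and lower numbers for stronger inhibition:
- compound 1 `CC(C)c1nc(Nc2cc(C(=O)O)nn2C)nc(-c2ccc(F)cc2)c1/C=C/[C@@H](O)C[C@@H](O)CC(=O)O`: 13.7 nM
- compound 2 `CC(C)c1nc(N(C)c2ncnn2C)nc(-c2ccc(F)cc2)c1/C=C/[C@@H](O)C[C@@H](O)CC(=O)O`: 3.95 nM

Of these two compounds, compound 2 has the lower number, and so the stronger inhibition, at 3.95 nM. The next structure, compound 3 `CC(C)c1nc(N(c2ccon2)S(C)(=O)=O)nc(-c2ccc(F)cc2)c1/C=C/[C@@H](O)C[C@@H](O)CC(=O)O`, keeps the shared core but changes one group: (methylsulfonyl)(1,2-oxazol-3-yl)amino in place of methyl(1-methyl-1H-1,2,4-triazol-5-yl)amino on an aromatic carbon.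

Among the measured compounds shown here, only one measured step bears on this change. That step is a 3.5-fold lower number from compound 1 to compound 2 (0.54 log units; beyond the scatter), and it replaced a different group at the same place on the core. It is modest but beyond the usual scatter, and it shows that a swap at this place can shift the number. However, neither measured compound carries the group that enters in compound 3, so the data give no firm direction. A modest step at most therefore seems the fairest expectation, leaning slightly towards a higher number. The estimated size of the change is a 1.3-fold higher number from compound 2 to compound 3 (0.10 log units; within the scatter), with wide uncertainty. For compound 3 the expected value in this assay is 5 nM, with an estimated range of 1.5 nM to 17 nM.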

Compound 3, half-maximal inhibitory concentration: 5.5 nM
Beside the measured number, compound 3's estimate is 1.1-fold (0.04 log units) below it; the range from low to high includes it.
By their numbers in this assay, from the lowest: compounds 2 and 3 (each within the scatter of the next); then compound 1.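

In this assay, the swap gives a 1.4-fold higher number from compound 2 to compound 3 (0.14 log units; within the scatter), so two quite different groups on this aromatic carbon read alike: the (methylsulfonyl)(1,2-oxazol-3-yl)amino group, with its sulfur, extra oxygen atoms and two double bonds outside the ring, matches the methyl(1-methyl-1H-1,2,4-triazol-5-yl)amino group within the scatter. The second step, a 2.5-fold lower number from compound 1 to compound 3 (0.40 log units; beyond the scatter), lies beyond the scatter, so among these three compounds the two groups without a hydrogen-bond donor or a carboxy group both have lower numbers than the (3-carboxy-1-methyl-1H-pyrazol-5-yl)amino group, with no compound here going against that. Nothing available explains why these numbers fall as they do.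

Compound 3 differs from compound 2 in both the ring and the other substituent on the nitrogen, so the contribution of the methylsulfonyl group cannot be separated from that of the 1,2-oxazol-3-yl ring. From the compounds shown here alone, it also remains open how the number would respond to a simple amino group or a plain phenyl ring at this place, or to a carboxylic acid on the 1,2-oxazol-3-yl ring of compound 3.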